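The compounds below may be only part of what the source reports. "The series", "measured", "known", "first", "only" and "open" are said of these compounds alone.

Among the compounds with values here, compound 1 `CC(NC(=O)c1ccc(-c2ccc(NC(=O)Nc3cc(C(F)(F)F)ccc3Cl)cc2)cc1)c1ccccc1` is one of three compounds measured in a functional assay on HepG2 cells (Homo sapiens) for inhibition, read by MTT assay, with a stated time of 120 h; a higher number here means a weaker inhibitor, a lower number a stronger inhibitor; compound 1 gives 18400 nM. Compound 2 `CC(NC(=O)/C=C/Oc1ccc(NC(=O)Nc2cc(C(F)(F)F)ccc2Cl)cc1)c1ccccc1` gives 11900 nM, and compound 3 `CC(NC(=O)/C=C/Oc1ccc(NC(=O)Nc2ccc(Cl)c(C(F)(F)F)c2)cc1)c1ccccc1` gives 14100 nM. Compound 1 and compound 2 stand on different cores, and the difference between the two cores is not broken down here. Compound 3 differs from compound 2 in one place, (4-chloro-3-(trifluoromethyl)phenyl in place of 2-chloro-5-(trifluoromethyl)phenyl on an amide-type nitrogen), with a step of a 1.2-fold higher number from compound 2 to compound 3 (0.07 log units; within the scatter). The same change occurs twice in the set: compound 4 `CC(NC(=O)c1ccc(-c2ccc(NC(=O)Nc3ccc(Cl)c(C(F)(F)F)c3)cc2)cc1)c1ccccc1`, not yet measured, differs from compound 1 by 4-chloro-3-(trifluoromethyl)phenyl in place of 2-chloro-5-(trifluoromethyl)phenyl on an amide-type nitrogen, made on the core of compound 1. Within the data shown here, the step from compound 1 to compound 4 in this assay is expected to resemble the earlier one, because a 1.2-fold higher number from compound 2 to compound 3 (0.07 log units; within the scatter) is the only guide available. The expected step is a 1.1-fold higher number from compound 1 to compound 4 (0.06 log units; within the scatter). Compound 4 is therefore estimated at 21000 nM, within a range of 10000 nM to 45000 nM.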

Compound 4, half-maximal inhibitory concentration: 16800 nM
Estimate against measurement, compound 4: 1.3-fold (0.10 log units) above; low and high end bracket the measured number.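

Exchanging 2-chloro-5-(trifluoromethyl)phenyl for 4-chloro-3-(trifluoromethyl)phenyl on the amide-type nitrogen gives, in this assay, a 1.1-fold lower number from compound 1 to compound 4 (0.04 log units; within the scatter). The two cores show no detectable difference in how they take this change: the same change on two cores in this assay, a 1.2-fold higher number (0.07 log units; within the scatter) from compound 2 to compound 3 and a 1.1-fold lower number (0.04 log units; within the scatter) from compound 1 to compound 4, 1.3-fold (0.11 log units) apart, within the scatter of two such steps. Within the data shown here, both steps lie within the scatter, so the pair shows only that the exchange leaves the number unresolved on both cores; it does not show that a change with a real effect would carry across, and two cores set no rule for the series.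

All four compounds keep chloro and trifluoromethyl groups on this phenyl ring. As far as these compounds go, whether a nitrile or an amine in place of either group would shift the number, and whether such a shift would carry between cores, remains open.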